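This account rests on a few compounds, and the source may have more. Where it says the series, first, only, none or still open, it means among the compounds named here.

Compound 1: `CN1CCc2oc(=O)n(C(=O)NCCCCc3ccccc3)c2C1` — 516 nM
Compound 2: `O=C(NCCCCc1ccccc1)n1c(=O)oc2cc(C3CCOCC3)ccc21` — 68 nM
Compound 3: `CN1CCC(c2ccc3c(c2)oc(=O)n3C(=O)NCCCCc2ccccc2)CC1=O` — 105 nM

All three were measured in an assay on HEK293 cells for inhibition of acid ceramidase (Homo sapiens), read by fluorescence, with stated times of 10 min and 3 h; on this read-out lower numbers stand for stronger inhibition and higher numbers for weaker inhibition. Compound 1 stands highest of the three numbers, and its gaps to both others lie beyond the scatter: compound 3 gives 105 nM and compound 2 gives 68 nM. Among the measured compounds shown here, the only single-point step among the measured compounds is a 1.5-fold higher number from compound 2 to compound 3 (0.19 log units; within the scatter), which exchanges one ring on an aromatic carbon of the core and leaves the result within the scatter.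

Compound 4, `O=C(NCCCCc1ccccc1)n1c2c(oc1=O)CCNC2`, differs from compound 1 in one place: hydrogen in place of methyl on an amine nitrogen in a ring. For the measured compounds named here, no measured step touches this amine nitrogen in a ring, so the data give no direct guide to the size or direction of the change; the one measured step concerns a different part of the core. On that basis no step beyond the scatter is expected. Compound 4 is therefore estimated at 500 nM, within a range from 200 nM to 1300 nM. This estimate means an expected step of a 1.0-fold lower number from compound 1 to compound 4 (0.01 log units; within the scatter).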

Compound 4, half-maximal inhibitory concentration: 247 nM
Beside the measured number, compound 4's estimate is 2.0-fold (0.31 log units) above it; the measured number falls inside the stated range.
By their numbers in this assay, from the lowest: compounds 2 and 3 (each within the scatter of the next); then compound 4; then compound 1.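

In this assay, among the compounds shown here, hydrogen in place of methyl on an amine nitrogen in a ring gives a 2.1-fold lower number from compound 1 to compound 4 (0.32 log units; beyond the scatter) and so provides the first measured change at this position. The step is modest but lies beyond the scatter, which shows that this nitrogen is a place where a small edit can shift the number, and that the methyl is not needed for the inhibition seen here. No measurement shown explains why removing the methyl lowers the number.

On these data alone, with only hydrogen and methyl on this nitrogen, the effect of an ethyl, cyclopropyl or acetyl group there remains open. So does whether a group on this nitrogen would alter the number in the same direction on a different core, such as those of compounds 2 and 3.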